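The source may hold more compounds than are shown below. What is called first, only, known or untested is meant among the compounds shown, and "the series" means these compounds.

Compound 1, `COc1cc(NC(=O)Nc2cc(Nc3ccc(C)c(C)c3)ncn2)cc(OC)c1`, gives 20.1% in a functional assay on NCI-H1581 cells (Homo sapiens) for inhibition, read by MTT assay, with a stated time of 48 h, tested at 10 uM; a higher number here means more inhibition at the concentration tested (going by the name of the read-out), a lower number less inhibition.
Compound 2, `COc1cc(NC(=O)Nc2cc(Nc3cccc(C(C)(C)C)c3)ncn2)cc(OC)c1`, gives 35.1% in this assay.
Compound 3, `COc1cc(NC(=O)Nc2cc(Nc3cc(F)ccc3OC)ncn2)cc(OC)c1`, gives 42.1% in this assay.

On the numbers alone compound 3 stands highest of the three, but its margin over compound 2 is a number 7 percentage points higher from compound 2 to compound 3 (within the scatter) and so does not separate the two compounds; its margin over compound 1 is a number 22 percentage points higher from compound 1 to compound 3 (beyond the scatter) and does. The two steps that lead away from compound 1 each replace the whole aryl group on the nitrogen: a number 15 percentage points higher from compound 1 to compound 2 (beyond the scatter) and a number 22 percentage points higher from compound 1 to compound 3 (beyond the scatter), both modest and both upward.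

Compound 4, `COc1cc(NC(=O)Nc2cc(Nc3cc(I)ccc3OC)ncn2)cc(OC)c1`, keeps everything of compound 3 except a single atom: iodo in place of fluoro on an aromatic carbon. For the measured compounds named here, no measured step bears directly on this change. Every step shown exchanges one aryl group for a different one, and none swaps one halogen for another while the rest of the ring is held fixed. The expectation for compound 4 in this assay therefore rests on compound 3 alone, and no step beyond the scatter is expected in either direction, so the estimated movement is a number 1.9 percentage points higher from compound 3 to compound 4 (within the scatter). Compound 4 is estimated at 44%, with a range from 25% to 63%.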

Compound 4, a percentage reported as inhibition, at one concentration (the size of the read-out at that concentration, not a potency): 59%
Compound 4: the middle estimate sits 15 percentage points below what was measured; the range from low to high includes it.
By their numbers in this assay, from the lowest: compound 1; then compounds 2 and 3 (each within the scatter of the next); then compound 4.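

For the compounds shown here, the exchange of fluoro for iodo, on the aromatic carbon para to a methoxy group and meta to a large group, is the first change here that holds the rest of the aryl ring fixed, and a number 16.9 percentage points higher from compound 3 to compound 4 (beyond the scatter) shows in this assay that this one position can move the number by itself, which the earlier exchanges of whole aryl groups could not isolate. Going by these compounds alone, compound 3 could not be separated from compound 2, whereas the 5-iodo-2-methoxyphenyl group stands clear of both other aryl groups, with a number 23.9 percentage points higher from compound 2 to compound 4 (beyond the scatter) and a number 38.9 percentage points higher from compound 1 to compound 4 (beyond the scatter), the second of these being the only large step in the set. Nothing shown accounts for the difference between iodo and fluoro at this carbon.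

The compounds shown leave open how chloro, bromo or an amine on this same carbon would read, and so whether the numbers follow any order among the halogens. They also leave open whether iodo would raise the number on the 3-(tert-butyl)phenyl ring, and, with one concentration as the only read-out, how compound 4 would compare as a matter of potency.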